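The source may hold more compounds than are shown below. What is called first, only, known or untested is meant among the compounds shown, and "the series" means these compounds.

Measured so far:
Compound 1 `Cc1ncc(C)n2nc(-c3ccc4nc(-c5ccccc5)[nH]c4c3)nc12` — in an ADME assay on microsomes from liver (Rattus norvegicus) for metabolic stability, read by LC-MS, in the presence of a further agent that is not named here (on this read-out higher numbers stand for fast clearance and lower numbers for slow clearance), compound 1 gives 27.4 mL.min-1.g-1.
Compound 3 `Cc1ncc(C)n2nc(-c3ccn4cc(-c5ccc(F)cc5)nc4n3)nc12` — in this assay compound 3 gives 3.1 mL.min-1.g-1.
Compound 2 `Cc1nc(-c2ccc3nc(-c4ccccc4)[nH]c3c2)nc2ccccc12` — in this assay compound 2 reaches only > 450 mL.min-1.g-1, which is a limit of the assay and not a number.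

Compound 3 stands lowest of the two numbers; the nearest number, that of compound 1, is higher by a gap beyond the usual scatter. Compound 4 `Cc1ncc(C)n2nc(-c3ccn4cc(-c5ccccc5Br)nc4n3)nc12` has not yet been measured. It differs from compound 3 in one place: 2-bromophenyl in place of 4-fluorophenyl on an aromatic carbon. Going by the values given here, no pair of measured compounds shows such a change, so no measured step guides the expectation. In this assay a modest rise is expected, of a size that may or may not exceed the scatter. Compound 4 is expected to give about 6.5 mL.min-1.g-1, between 2.5 mL.min-1.g-1 and 18 mL.min-1.g-1. The expected step is a 2.1-fold higher number from compound 3 to compound 4 (0.32 log units; beyond the scatter).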

Compound 4, intrinsic clearance in microsomes: 1.8 mL.min-1.g-1
For compound 4 the middle estimate is 3.6-fold (0.56 log units) above the measured one; the whole stated range lies above it.
By their numbers in this assay, from the lowest: compounds 4 and 3 (each within the scatter of the next); then compound 1. At a limit, above all of these: compound 2.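

In this assay, putting 2-bromophenyl in place of 4-fluorophenyl on this aromatic carbon gives a 1.7-fold lower number from compound 3 to compound 4 (0.24 log units; within the scatter). Going by these compounds alone, this is the first measured change at this position, and it shows that this exchange of substituted phenyl groups leaves the read-out within the scatter. Nothing measured here accounts for this outcome.

The step changes the halogen and its place on the phenyl ring together, so their contributions cannot be separated. As far as these compounds go, whether an amine or a carboxylic acid on that phenyl ring would be tolerated equally remains open.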